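The source may report more compounds than this note shows. Statements on the series, on what has been measured and on what is new or still open speak of the compounds shown alone.

Series notes. Compound 1 `CCCSc1nc(N/N=C(\C)c2ccccc2O)c2nnn(Cc3ccc(O)cc3)c2n1` in a functional assay on MCF7 cells (Homo sapiens) for antiproliferative activity, read by MTT assay, with a stated time of 72 h (on this read-out lower numbers stand for stronger inhibition and higher numbers for weaker inhibition), gives 9520 nM. Compound 2 `CCCSc1nc(N/N=C/c2cccs2)c2nnn(Cc3ccccc3)c2n1` in this assay gives only a limit, > 64000 nM. At the limit of > 64000 nM in this assay, at which 1 of the 2 values shown sits, stands, so no number is available for compound 2.

Compound 3 `CCCSc1nc(N/N=C(\C)c2ccccc2O)c2nnn(Cc3ccccc3)c2n1` is unmeasured; it follows from compound 2 by a group of 10 heavy atoms (8 carbon, 1 nitrogen, 1 oxygen; one six-membered aromatic ring of carbon only) in place of a group of 7 heavy atoms (5 carbon, 1 nitrogen, 1 sulfur; one five-membered aromatic ring with 1 hetero atom), on a nitrogen on an aromatic ring. Among the compounds with values here, the entering group is the one carried by compound 1, which gives 9520 nM, so a gain is expected for compound 3, with a step of an at least 4.5-fold lower number from compound 2 to compound 3 (0.66 log units; beyond the scatter). The expected value for compound 3 is 14000 nM, within 5000 nM to 40000 nM.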

Compound 3, half-maximal inhibitory concentration: 11000 nM
Compound 3: the middle estimate sits 1.3-fold (0.10 log units) above what was measured; the measured number falls inside the stated range.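

At the nitrogen on an aromatic ring, the group with a six-membered aromatic ring of carbon only, in place of the group with a five-membered aromatic ring with 1 hetero atom, gives an at least 5.8-fold lower number from compound 2 to compound 3 (0.76 log units; beyond the scatter), a real gain in this assay. That step is only a bound, as compound 2 gives a limit and not a number: the limit of > 64000 nM in this assay, at which 1 of the 3 values shown sits. Hydrogen in place of hydroxy on an aromatic carbon gives a 1.2-fold higher number from compound 1 to compound 3 (0.06 log units; within the scatter), so this change leaves the number unmoved.

Which part of the entering group carries the gain stays open. So does the effect of an amine or a carboxylic acid in place of that hydroxy.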